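The compounds below may be only part of what the source reports. "The series", "measured", "known", "first", "only" and "open" are said of these compounds alone.

For the measured compounds named here, in an assay on isolated protein for inhibition of thyroid hormone receptor beta (Homo sapiens), read by fluorescence, with a stated time of 30 min (on this read-out higher numbers stand for weaker inhibition and lower numbers for stronger inhibition), compound 3 `COc1cc(C(=O)N2CCCC2(C)C)cc2nc(NCc3cccc(Cl)c3)oc12` gives 47 nM, the lowest of the three numbers so far; compound 2 `O=C(NCc1cccc(Cl)c1)c1ccc2cn(CCn3cccn3)nc2c1` gives 173 nM and compound 1 `O=C(NCc1cccc(Cl)c1)c1ccc2cn(CCN3CCOC3=O)nc2c1` gives 220 nM, both beyond the scatter above it, so compound 3 is the strongest measured. Compound 4 `COc1cc(C(=O)N2CCC(O)C(C)C2)cc2nc(NCc3cccc(Cl)c3)oc12` differs from compound 3 by 4-hydroxy-3-methylpiperidin-1-yl in place of 2,2-dimethylpyrrolidin-1-yl on a carbonyl carbon. Going by the values given here, the only measured step, a 1.3-fold lower number from compound 1 to compound 2 (0.10 log units; within the scatter), lies within the scatter and concerns a different part of a different core, so no step directly bears on this change. With nothing pointing either way, compound 4 is expected to sit close to compound 3, a step of a 1.6-fold higher number from compound 3 to compound 4 (0.20 log units; within the scatter), with a wide range. The estimate for compound 4 is therefore 75 nM, ranging from 20 nM to 280 nM.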

Compound 4, half-maximal inhibitory concentration: 25 nM
Beside the measured number, compound 4's estimate is 3.0-fold (0.48 log units) above it; the range from low to high includes it.
By their numbers in this assay, from the lowest: compounds 4 and 3 (each within the scatter of the next); then compounds 2 and 1 (each within the scatter of the next).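

At this place, on a carbonyl carbon, 4-hydroxy-3-methylpiperidin-1-yl and 2,2-dimethylpyrrolidin-1-yl cannot be told apart in this assay (a 1.9-fold lower number from compound 3 to compound 4 (0.27 log units; within the scatter)). A six-membered ring with a hydrogen-bond donor and acceptor can therefore replace a five-membered ring with neither, without a change beyond the scatter. Nothing here explains this result. Still open, on these data alone, is whether the hydroxy or the methyl group alone would give the same reading. Also open, as far as these compounds go, is how a ring carrying an amine or a carboxylic acid would read at this place.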